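Aminophenyl benzothiazoles: swapping the cyano for a silyl alkyne

The compounds below may be only part of what the source reports. "The series", "measured", "known", "first", "only" and "open" are said of these compounds alone.

Of the compounds shown here, two have been measured in a functional assay on MCF7 cells (Homo sapiens) for inhibition, with a stated time of 72 h; on this read-out lower numbers stand for stronger inhibition of growth and higher numbers for weaker inhibition of growth. Compound 1 `C[Si](C)(C)C#Cc1cc(-c2nc3ccccc3s2)ccc1N` gives 710 nM. Compound 2 `N#Cc1cc(-c2nc3c(F)cccc3s2)ccc1N` gives 180 nM and so stands at the lowest of the two numbers, with compound 1 the nearest at a higher number that lies beyond the usual scatter. Compound 1 and compound 2 differ in two places at once, so neither difference can be read off on its own from these two values.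

Compound 3 `C[Si](C)(C)C#Cc1cc(-c2nc3c(F)cccc3s2)ccc1N` keeps the fluorinated core of compound 2 and carries the change (a group of 6 heavy atoms (5 carbon, 1 silicon; no ring) in place of a group of 2 heavy atoms (1 carbon, 1 nitrogen; no ring), on an aromatic carbon). The group that enters, of 6 heavy atoms with no hydrogen-bond acceptor, is the same one found in compound 1.

For the measured compounds named here, no single-point step between measured compounds is available, so the direction of a 2.2-fold higher number from compound 2 to compound 3 (0.35 log units; beyond the scatter) is expected to be a modest rise in the number, since the only compound bearing the entering group, compound 1, gives 710 nM. Compound 3 is therefore estimated at 400 nM, with a range from 150 nM to 1200 nM.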

Compound 3, concentration for 50% growth inhibition: 520 nM
Compound 3: the middle estimate sits 1.3-fold (0.11 log units) below what was measured; the measured number falls inside the stated range.
By their numbers in this assay, from the lowest: compound 2; then compounds 3 and 1 (each within the scatter of the next).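

In this assay, for the compounds shown here, the step of a 2.9-fold higher number from compound 2 to compound 3 (0.46 log units; beyond the scatter) gives the first reading of this position with the rest of the molecule held constant: replacing cyano with the silyl alkyne group, on the aromatic carbon ortho to an amino group, weakens growth inhibition. The other single change, fluoro in place of hydrogen on an aromatic carbon, gives a 1.4-fold lower number from compound 1 to compound 3 (0.14 log units; within the scatter), so this pair shows no separable effect of the fluoro. Of the two single changes shown, only the one at the position ortho to an amino group reaches beyond the scatter.

Nothing measured here bears on why the number moves with this change. The compounds shown leave open whether the step follows the silicon, the size of the entering group or the hydrogen-bond acceptor that leaves with cyano, how an amine, a carboxylic acid or a plain ethynyl group would read at this position, and whether the fluoro reading would hold with cyano in place.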